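The source may report more compounds than this note shows. Statements on the series, on what has been measured and on what is new or still open speak of the compounds shown alone.

Measured compounds:
- compound 1, `Nc1nc(O)c2c(n1)n(C1OC(CO)[C@@H](O)[C@H]1O)c(=O)n2C/C=C/c1ccccc1`, 103 uM 
- compound 2, `[N-]=[N+]=NCC(O)Cn1c(=O)n(C2OC(CO)[C@@H](O)[C@H]2O)c2nc(N)nc(O)c21`, 39 uM 
- compound 3, `Nc1nc(O)c2c(n1)n(C1OC(CO)[C@@H](O)[C@H]1O)c(=O)n2CC(O)CO`, 45 uM 

All three were tested in a functional assay (B cells) with Mus musculus as the target; a lower number here means that less compound is needed, a higher number that more compound is needed for the effect. Compound 3 stands second highest of the three numbers: its nearest neighbour is compound 2, with a 1.2-fold higher number from compound 2 to compound 3 (0.06 log units; within the scatter), a difference within the scatter, while compound 1 lies furthest away, with a 2.3-fold lower number from compound 1 to compound 3 (0.36 log units; beyond the scatter). Among the measured compounds shown here, the only compound carrying an aromatic ring on the chain, compound 1, gives the highest number, and its two neighbours, compound 2 and compound 3, are within the scatter of each other.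

Compound 4, `Nc1nc(O)c2c(n1)n(C1OC(CO)[C@@H](O)[C@H]1O)c(=O)n2CC(O)CSc1ccccc1`, is not yet measured. It differs from compound 3 in one place: phenylsulfanyl in place of hydroxy on a saturated chain carbon, two bonds along the chain from an oxygen on a saturated carbon. For the measured compounds named here, the steps that bear on this are a 2.3-fold lower number from compound 1 to compound 3 (0.36 log units; beyond the scatter) and a 2.6-fold lower number from compound 1 to compound 2 (0.42 log units; beyond the scatter), both modest and both beyond the scatter, in which removing the 2-phenylethenyl group lowered the number. Reintroducing an aromatic ring on the chain, now as phenylsulfanyl, is therefore expected to move the number of compound 4 back up, modestly, in the direction of compound 1, with a 1.8-fold higher number from compound 3 to compound 4 (0.25 log units; within the scatter). The estimate for compound 4 in this assay is 80 uM, with a range from 35 uM to 180 uM.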

Compound 4, concentration for half-maximal effect: 142 uM
Estimate against measurement, compound 4: 1.8-fold (0.25 log units) below; measured number inside the range.
By their numbers in this assay, from the lowest: compounds 2 and 3 (each within the scatter of the next); then compounds 1 and 4 (each within the scatter of the next).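

In this assay, phenylsulfanyl at this place, on a saturated chain carbon two bonds along the chain from an oxygen on a saturated carbon, gives a result that can be told apart from both smaller groups, with a 3.2-fold higher number from compound 3 to compound 4 (0.50 log units; beyond the scatter) and a 3.6-fold higher number from compound 2 to compound 4 (0.56 log units; beyond the scatter), whereas hydroxy and azido there stay within the scatter of each other. The step of a 1.4-fold higher number from compound 1 to compound 4 (0.14 log units; within the scatter) puts compound 4 together with compound 1, so among these four compounds the two chains carrying a six-membered aromatic ring of carbon only form one group and the two without such a ring form another, and none of the four goes against this split. Nothing at hand gives a reason for this split.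

The compounds shown do not separate the contribution of the sulfur from that of the ring, which a methylsulfanyl or a phenoxy group at this place would address. As far as these compounds go, it also remains open whether an amine, a carboxylic acid or a longer chain there would fall with compound 2 and compound 3 or with compound 1 and compound 4.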